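Fluorine on the anilide ring of compound 2

This account rests on a few compounds, and the source may have more. Where it says the series, first, only, none or still open, it means among the compounds named here.

Measured so far:
compound 1 `Cc1ccc(-n2nc(C(=O)Nc3ccc(Oc4ncnc5[nH]ccc45)cc3)c(C)cc2=O)cc1`: 7460 nM
compound 2 `Cc1cc(=O)n(-c2ccc(Br)cc2F)nc1C(=O)Nc1ccc(Oc2ncnc3[nH]ccc23)cc1`: 3660 nM

In a functional assay on HepG2 cells (Homo sapiens) for cytotoxicity, read by MTT assay, with a stated time of 72 h (on this read-out higher numbers stand for weaker inhibition and lower numbers for stronger inhibition), compound 1 gives 7460 nM. Going by the values given here, compound 2 gives 3660 nM, the lowest of the two numbers so far, with compound 1 as its only neighbour. Among the compounds with values here, the single measured step, a 2.0-fold lower number from compound 1 to compound 2 (0.31 log units; beyond the scatter), follows an exchange of the aryl group on the aromatic nitrogen and is modest.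

Compound 3 `Cc1cc(=O)n(-c2ccc(Br)cc2F)nc1C(=O)Nc1ccc(Oc2ncnc3[nH]ccc23)c(F)c1` keeps the whole of compound 2 and differs only by fluoro in place of hydrogen on an aromatic carbon. Within the data shown here, no measured step touches this part of the scaffold, so the one step available does not bear on the change directly; it only shows that single-site edits have so far moved this assay by a modest amount. A step of no more than the scatter is therefore expected, a 1.0-fold lower number from compound 2 to compound 3 (0.02 log units; within the scatter), in either direction. For compound 3 in this assay the estimate is 3500 nM, with a range from 1500 nM to 8000 nM.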

Compound 3, half-maximal inhibitory concentration: 32000 nM
The estimate for compound 3 lay 9.1-fold (0.96 log units) below the measured number; measured number outside the range, above it.
By their numbers in this assay, from the lowest: compound 2; then compound 1; then compound 3.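

In this assay an 8.7-fold higher number from compound 2 to compound 3 (0.94 log units; beyond the scatter) shows that this aromatic carbon, ortho to a large group and meta to a large group, is not indifferent to substitution: fluoro in place of hydrogen, a single heavy atom, is enough to raise the number. This step runs in the opposite direction to the exchange of aryl groups on the aromatic nitrogen, and it is larger than that exchange, a 2.0-fold lower number from compound 1 to compound 2 (0.31 log units; beyond the scatter); the earlier step therefore gave no measure of how far this site can move the read-out. No measurement available here accounts for the rise.

From the compounds shown here alone, whether the rise is particular to fluoro or follows any group on this carbon stays open; chloro, methyl or an amine at the same place would separate the two. Also open, going by these compounds, is whether fluoro here has the same effect with the 4-methylphenyl group of compound 1 on the aromatic nitrogen.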